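Heteroaryl swap on the benzyl group: compound 3

The source may report more compounds than this note shows. Statements on the series, on what has been measured and on what is new or still open speak of the compounds shown alone.

Measured so far in an assay on microsomes from intestine for inhibition of acyl-CoA:cholesterol acyltransferase (Oryctolagus cuniculus); a higher number here means a weaker inhibitor, a lower number a stronger inhibitor:
compound 1 `Cc1cc(C)c(NC(=O)N(Cc2ccc(-c3n[nH]c(C)n3)cc2)C2CCCCCC2)c(C)c1` gives 120 nM
compound 2 `Cc1cc(C)c(NC(=O)N(Cc2cccc(-c3nnn(C)n3)c2)C2CCCCCC2)c(C)c1` gives 100 nM

Compound 1 holds the higher of the two numbers, but its gap to compound 2 lies within the scatter, so the two values show no difference. Compound 3 `Cc1cc(C)c(NC(=O)N(Cc2ccc(-c3cn[nH]c3)cc2)C2CCCCCC2)c(C)c1` is not yet measured. It differs from compound 1 in one place: 1H-pyrazol-4-yl in place of 5-methyl-1H-1,2,4-triazol-3-yl on an aromatic carbon. Going by the values given here, no measured step of this kind exists, so the data give no direction; a step within the scatter, either way, is expected in this assay. For compound 3 in this assay the estimate is 150 nM, range 60 nM to 400 nM. The expected step is a 1.3-fold higher number from compound 1 to compound 3 (0.10 log units; within the scatter).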

Compound 3, half-maximal inhibitory concentration: 270 nM
Beside the measured number, compound 3's estimate is 1.8-fold (0.26 log units) below it, within the range that was stated.
By their numbers in this assay, from the lowest: compounds 2 and 1 (each within the scatter of the next); then compound 3.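

In this assay, going by these compounds alone, the group on the aromatic carbon para to a large group is not freely exchangeable: 1H-pyrazol-4-yl in place of 5-methyl-1H-1,2,4-triazol-3-yl gives a 2.3-fold higher number from compound 1 to compound 3 (0.35 log units; beyond the scatter) as a modest step, the first readable step. No measured evidence bears on the origin of this step. The change replaces the whole ring, so the contribution of the methyl group cannot be separated from that of the ring itself. Also open, from the compounds shown here alone, is how a carboxylic acid or an aminomethyl group would read at this place.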